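Compound 3 to compound 4: from formyl to cyclohexylcarbonyl

The compounds below may be only part of what the source reports. "The series", "measured", "known", "first", "only" and "open" are said of these compounds alone.

Values measured in a functional assay on THP-1 cells (Homo sapiens) for inhibition, with a stated time of 4 h; a higher number here means a weaker inhibitor, a lower number a stronger inhibitor:
- compound 1 `O=C(CN1CCCN(C(=O)c2ccccc2)C[C@H](NC(=O)c2ccccc2)C1=O)N[C@H]1CC(=O)OC1O`: 1020 nM
- compound 2 `Cc1ccc(Cl)cc1C(=O)N[C@H]1CN(C(=O)c2ccccc2)CCCN(CC(=O)N[C@H]2CC(=O)OC2O)C1=O`: 298 nM
- compound 3 `O=CN1CCCN(CC(=O)N[C@H]2CC(=O)OC2O)C(=O)[C@@H](NC(=O)c2ccc3ccccc3c2)C1`: 219 nM

Compound 3 cannot be separated from compound 2 within the scatter, and both give clearly lower numbers than compound 1. Compound 4 `O=C(CN1CCCN(C(=O)C2CCCCC2)C[C@H](NC(=O)c2ccc3ccccc3c2)C1=O)N[C@H]1CC(=O)OC1O` has cyclohexyl in place of hydrogen on a carbonyl carbon. Among the measured compounds shown here, the only measured step, a 3.4-fold lower number from compound 1 to compound 2 (0.53 log units; beyond the scatter), is modest and lies at a different carbonyl carbon, so it bears on this change only loosely. Compound 2, at 298 nM, has phenyl on the carbonyl carbon in question and differs elsewhere too, yet it stays within the scatter of compound 3, at 219 nM. No step beyond the scatter is therefore expected in this assay. The estimate is a 1.1-fold lower number from compound 3 to compound 4 (0.04 log units; within the scatter), an expected change inside the scatter. For compound 4 the expected value is 200 nM, with an estimated range of 70 nM to 600 nM.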

Compound 4, half-maximal inhibitory concentration: 577 nM
Beside the measured number, compound 4's estimate is 2.9-fold (0.46 log units) below it; low and high end bracket the measured number.
By their numbers in this assay, from the lowest: compounds 3, 2, 4 and 1 (each within the scatter of the next, the first and the last beyond it).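

In this assay, cyclohexyl in place of hydrogen on this carbonyl carbon gives a 2.6-fold higher number from compound 3 to compound 4 (0.42 log units; beyond the scatter), a modest step beyond the scatter. Among the compounds shown here, no earlier pair differed at this place alone, so this is the first direct sign that the group carried here moves the number, and that the formyl compound holds the better value of the two. Nothing measured accounts for the step. On these data alone, whether methyl, a longer open chain or an amine on this carbonyl carbon would stand nearer compound 3 or compound 4 stays open. So does whether the step would hold with the other aryl amides of compound 1 and compound 2.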